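Swapping 4-aminophenyl for 2-methylphenyl in compound 3

This account rests on a few compounds, and the source may have more. Where it says the series, first, only, none or still open, it means among the compounds named here.

Compound 1 `O=C(O)CCCCc1cn(CC(=O)NCc2ccccc2)nn1`: 1080 uM
Compound 2 `Nc1ccc(-c2cn(CC(=O)NCc3ccccc3)nn2)cc1`: 1240 uM

Both values come from an ADME assay on cells (spleen, Mus musculus, strain C57BL/6) for inhibition, read by flow cytometry and propidium iodide staining, with a stated time of 24 h, at 37 degrees C; on this read-out higher numbers stand for an effect only at larger amounts of compound and lower numbers for an effect already at smaller amounts. Compound 2 stands within the scatter of compound 1, so the two cannot be ranked.

Compound 3 `Cc1ccccc1-c1cn(CC(=O)NCc2ccccc2)nn1` keeps the shared core of compound 2 but has 2-methylphenyl in place of 4-aminophenyl on an aromatic carbon, next to the ring nitrogen of a five-membered aromatic ring with 3 nitrogen (2-methylphenyl in place of 4-aminophenyl on an aromatic carbon). Among the measured compounds shown here, only one measured step bears on this change: a 1.1-fold higher number from compound 1 to compound 2 (0.06 log units; within the scatter). That step put 4-aminophenyl in place of 4-carboxybutyl on the same aromatic carbon, and the values stayed within the scatter. For the measured compounds named here, two compounds are a thin basis, and no measured compound carries 2-methylphenyl. On this evidence, no step beyond the scatter is expected in this assay, and no direction can be named. The expected change is a 1.1-fold lower number from compound 2 to compound 3 (0.05 log units; within the scatter). For compound 3 the estimated value is 1100 uM, with an expected range from 500 uM to 2400 uM.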

Compound 3, concentration for half-maximal effect: 940 uM
For compound 3 the middle estimate is 1.2-fold (0.07 log units) above the measured one; low and high end bracket the measured number.
By their numbers in this assay, from the lowest: compounds 3, 1 and 2 (each within the scatter of the next).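

At this aromatic carbon, this assay gives a 1.3-fold lower number from compound 2 to compound 3 (0.12 log units; within the scatter): the hydrogen-bond donor and acceptor counted on 4-aminophenyl are absent from 2-methylphenyl, yet the two values cannot be told apart. The comparison with the open chain gives the same picture, with a 1.1-fold lower number from compound 1 to compound 3 (0.06 log units; within the scatter), so 4-carboxybutyl, 4-aminophenyl and 2-methylphenyl at this one position all give values that cannot be ranked against one another. No separate measurement is available to explain this result.

These three compounds do not show whether a different group on the same carbon, such as a hydroxyl, a nitrile or a longer chain, would give a step beyond the scatter. The rest of the shared core is identical in all three compounds, so these values say nothing about what a change elsewhere in the structure would do.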